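Phenyl in place of furan-3-yl on a shared core

A few compounds are considered here, and "the series" means these few. Any claim that something is new, unique, unknown or untested is made for them only; others in the source may bear on it.

Compound 1 `Nc1nc(N)c2c(-c3cc4ccccc4o3)cn([C@@H]3O[C@H](CO)[C@@H](O)[C@H]3O)c2n1`: in a functional assay on K562 cells (Homo sapiens), read by MTT assay, with a stated time of 72 h (a lower number here means a stronger inhibitor, a higher number a weaker inhibitor), compound 1 gives > 20000 nM, which is a limit of the assay rather than a number.
Compound 2 `Nc1nc2c(c(-c3ccccc3)cn2[C@@H]2O[C@H](CO)[C@@H](O)[C@H]2O)c(=O)[nH]1`: in this assay compound 2 gives > 20000 nM, again a limit.
Compound 3 `Nc1nc(N)c2c(-c3ccoc3)cn([C@@H]3O[C@H](CO)[C@@H](O)[C@H]3O)c2n1`: in this assay compound 3 gives > 20000 nM, also a limit.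

Compound 3 therefore stands at the same limit as both other compounds, with no measurable number. For the measured compounds named here, the single recorded step, a step that the two limits leave unreadable from compound 1 to compound 3, cannot be sized because the limit of > 20000 nM in this assay, at which 3 of the 3 values shown sit, covers both of its ends.

Compound 4 `Nc1nc(N)c2c(-c3ccccc3)cn([C@@H]3O[C@H](CO)[C@@H](O)[C@H]3O)c2n1` differs from compound 3 by phenyl in place of furan-3-yl on an aromatic carbon. Going by the values given here, compound 2 carries the same phenyl group on a different core and shows only a limit, so no measured step bears on this change. In this assay compound 4 is expected to sit at 30000 nM, between 10000 nM and 100000 nM, most likely reported only as a limit. The step that the limit leaves unreadable from compound 3 to compound 4 is thus expected to stay within the scatter.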

Compound 4, half-maximal inhibitory concentration: > 20000 nM
Compound 4: only a limit was reported; the forecaster's own chance of this, stated with the estimate: 85%; the middle value is on the limit's open side.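

Compound 4 also gives only a limit, so the steps to it from compound 1 and compound 3 cannot be read: the limit of > 20000 nM in this assay, at which 4 of the 4 values shown sit. The compounds shown leave open how 1-benzofuran-2-yl, furan-3-yl and phenyl compare in this assay.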